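This account rests on a few compounds, and the source may have more. Where it says the series, first, only, none or still open, it means among the compounds named here.

Values measured in a functional assay on A549 cells (Homo sapiens) for inhibition, read by MTT assay, with a stated time of 48 h; on this read-out lower numbers stand for stronger inhibition and higher numbers for weaker inhibition:

- Compound 1 `COc1ccc2c(=O)c(/C=C/C(=O)Nc3cccc(Cl)c3)coc2c1`: 470 nM
- Compound 2 `COc1ccc2c(=O)c(/C=C/C(=O)NCc3ccc(C)cc3)coc2c1`: > 100000 nM (a limit of the assay)
- Compound 3 `COc1ccc2c(=O)c(/C=C/C(=O)Nc3ccccc3C)coc2c1`: 23400 nM

Among the two true numbers in this assay, compound 3 holds the higher, at 23400 nM. The other number is a 50-fold higher number from compound 1 to compound 3 (1.70 log units; beyond the scatter). The value of compound 2 is a limit (the limit of > 100000 nM in this assay, at which 1 of the 3 values shown sits), and an at least 4.2-fold lower number from compound 2 to compound 3 (0.63 log units; beyond the scatter) is therefore only a bound.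

Compound 4 `COc1ccc2c(=O)c(/C=C/C(=O)Nc3ccc(C)cc3)coc2c1` shares its core with the other three and has 4-methylphenyl in place of 2-methylphenyl on an amide-type nitrogen. Among the compounds with values here, none of the measured steps makes this exact exchange, but all three change the group on that same nitrogen. They show that the read-out can move strongly there, with an at least 210-fold higher number from compound 1 to compound 2 (2.32 log units; beyond the scatter) as the largest. Compound 1, at 470 nM, shows that a substituted phenyl on this nitrogen can reach a far lower number than compound 3 does. Within the data shown here, a lower number for compound 4 is therefore expected, though a much smaller move than the one seen with compound 1, and the evidence for its direction is thin. The expected step is a 3.9-fold lower number from compound 3 to compound 4 (0.59 log units; beyond the scatter), an estimate.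

For compound 4 the estimated value is 6000 nM, with an expected range of 800 nM to 40000 nM.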

Compound 4, half-maximal inhibitory concentration: 17500 nM
The estimate for compound 4 lay 2.9-fold (0.46 log units) below the measured number, and the stated range covers the measured number.
By their numbers in this assay, from the lowest: compound 1; then compounds 4 and 3 (each within the scatter of the next). At a limit, above all of these: compound 2.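

In this assay, 4-methylphenyl in place of 2-methylphenyl on the amide-type nitrogen gives a 1.3-fold lower number from compound 3 to compound 4 (0.13 log units; within the scatter), so these two methylphenyl groups cannot be told apart on this read-out, and compound 4 stays far from the 3-chlorophenyl compound, with a 37-fold higher number from compound 1 to compound 4 (1.57 log units; beyond the scatter). Together with compound 3, compound 4 therefore shows that a methyl-bearing phenyl at this nitrogen, whichever of these two forms it takes, does not reach the low number of compound 1. The exchange of 4-methylbenzyl for 4-methylphenyl gives an at least 5.7-fold lower number from compound 2 to compound 4 (0.75 log units; beyond the scatter), which can be read only as a bound, and the value of compound 2 is a limit: the limit of > 100000 nM in this assay, at which 1 of the 4 values shown sits.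

The compounds shown leave open whether the low number of compound 1 follows from the chlorine itself or from where it stands, a question that 3-methylphenyl, 4-chlorophenyl and 2-chlorophenyl on the same nitrogen would address. They also leave open how an unsubstituted phenyl or a 3-methoxyphenyl, or a 3-bromophenyl or 3-fluorophenyl in place of the 3-chlorophenyl, would read in this assay.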